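Removing a Chain Methyl: Expected Half-Life of Compound 4

The source may report more compounds than this note shows. Statements on the series, on what has been measured and on what is new or still open speak of the compounds shown alone.

Three compounds built on one shared core have been examined in an ADME assay on isolated protein for pharmacokinetics, with UDP-glucuronosyltransferase 1A9 (Homo sapiens) as the target, read by LC-MS, with a stated time of 60 min, at 37 degrees C, tested at 1 uM, in the presence of a further agent that is not named here; a higher number here means that the compound lasts longer, a lower number that the compound disappears faster. Compound 1 `NS(=O)(=O)CC(=O)NCCSc1nonc1/C(=N/O)Nc1cccc(C(F)F)c1` carries a difluoromethyl group on an aromatic carbon, and in this assay compound 1 returns > 3 h, which is a limit of the assay and not a number. Compound 2 `NS(=O)(=O)CC(=O)NCCSc1nonc1/C(=N/O)Nc1cccc(Cl)c1`, with chloro in place of difluoromethyl on an aromatic carbon, gives 0.9 h in this assay. The step of an at least 3.3-fold lower number from compound 1 to compound 2 (0.52 log units; beyond the scatter) is thus at least modest, although one end of it rests on a limit (the limit of > 3 h in this assay, at which 1 of the 3 values shown sits). Compound 3 `C[C@H](CSc1nonc1/C(=N/O)Nc1ccc(F)c(Br)c1)NC(=O)CS(N)(=O)=O`, which bears a methyl on a saturated chain carbon, gives 1.33 h in this assay; of the two plain numbers reported, it sits nearest compound 2 and within the usual scatter of that value.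

Compound 4 `NS(=O)(=O)CC(=O)NCCSc1nonc1/C(=N/O)Nc1ccc(F)c(Br)c1` differs from compound 3 by a single change: hydrogen in place of methyl on a saturated chain carbon bound to an amide-type nitrogen and a saturated chain carbon. For the measured compounds named here, none of the measured steps concerns this part of the molecule; the only measured step, an at least 3.3-fold lower number from compound 1 to compound 2 (0.52 log units; beyond the scatter), involves an aromatic substituent and says nothing about the chain. From this change no step beyond the scatter is expected in this assay. The estimate for compound 4 is therefore 1.2 h, with a range from 0.6 h to 2.5 h, meaning an expected step of a 1.1-fold lower number from compound 3 to compound 4 (0.04 log units; within the scatter).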

Compound 4, half-life: 0.758 h
Estimate against measurement, compound 4: 1.6-fold (0.20 log units) above, and the stated range covers the measured number.
By their numbers in this assay, from the lowest: compounds 4, 2 and 3 (each within the scatter of the next). At a limit, above all of these: compound 1.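

In this assay, for the compounds shown here, the pair of compound 3 and compound 4 gives the first direct reading at this saturated chain carbon: a 1.8-fold lower number from compound 3 to compound 4 (0.24 log units; within the scatter), so hydrogen in place of methyl here stays within what repeated measurements would give. Compound 4 also adds a reading on the amine nitrogen, where a 1.2-fold lower number from compound 2 to compound 4 (0.07 log units; within the scatter) places 3-bromo-4-fluorophenyl and 3-chlorophenyl within the scatter of each other, whereas an at least 3.9-fold lower number from compound 1 to compound 4 (0.59 log units; beyond the scatter) separates 3-bromo-4-fluorophenyl from 3-(difluoromethyl)phenyl beyond the scatter. Compound 1 stands at a limit and not at a number, so this last step gives only a lower bound on the difference: the limit of > 3 h in this assay, at which 1 of the 4 values shown sits.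

The compounds shown leave open whether an ethyl group, a longer chain or an amine on this same saturated chain carbon would also stay within the scatter of hydrogen and methyl. They also leave open how far the half-life of compound 1 reaches, and whether hydrogen in place of methyl would give a similar step with 3-(difluoromethyl)phenyl on the amine nitrogen.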